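A Methyl Added to the Ethylamino Chain

The compounds below may be only part of what the source reports. "The series", "measured", "known", "first", "only" and "open" are said of these compounds alone.

Compound 1 `CCNC(=O)c1noc(-c2cc(C(C)C)c(O)cc2O)c1-c1cc(CO)no1` gives 5 nM in a functional assay on A2780 cells (Homo sapiens) for inhibition (a higher number here means a weaker inhibitor, a lower number a stronger inhibitor), and compound 2 `CCNCc1cc(-c2c(C(=O)NCC)noc2-c2cc(C(C)C)c(O)cc2O)on1` gives 45 nM there. Compound 2 thus has the higher number of the two and is the weaker inhibitor. Going by the values given here, the only measured step is a 9.0-fold higher number from compound 1 to compound 2 (0.95 log units; beyond the scatter) with ethylamino in place of hydroxy on a saturated chain carbon bound to an aromatic carbon. Compound 3 `CCNC(=O)c1noc(-c2cc(C(C)C)c(O)cc2O)c1-c1cc(CNC(C)C)no1` has not yet been measured. Its difference from compound 2 is methyl in place of hydrogen on a saturated chain carbon bound to an amine nitrogen and a saturated chain carbon and this turns ethylamino into isopropylamino. The measured step bears on this change only loosely, as it swaps hydroxy for an amine and does not vary the group on the nitrogen. Among the compounds with values here, no measured pair tests ethyl against isopropyl, so the expectation starts from compound 2 at 45 nM and adds no shift of its own. The estimated 1.1-fold lower number from compound 2 to compound 3 (0.05 log units; within the scatter) is therefore expected to stay within the scatter, with a wide margin for the lack of direct data. Compound 3 is expected at 40 nM in this assay with an estimated range from 14 nM to 120 nM as its likely span.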

Compound 3, half-maximal inhibitory concentration: 38 nM
The estimate for compound 3 lay 1.1-fold (0.02 log units) above the measured number; measured number inside the range.
By their numbers in this assay, from the lowest: compound 1; then compounds 3 and 2 (each within the scatter of the next).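

In this assay, going by these compounds alone, the change from ethylamino to isopropylamino comes to a 1.2-fold lower number from compound 2 to compound 3 (0.07 log units; within the scatter) and so stays inside the usual scatter; this is the first pair in which the group on the amine nitrogen varies, and the added methyl on the saturated chain carbon leaves no difference that this assay can resolve. With hydroxy in place of the amine, the comparison gives a 7.6-fold higher number from compound 1 to compound 3 (0.88 log units; beyond the scatter) and, like a 9.0-fold higher number from compound 1 to compound 2 (0.95 log units; beyond the scatter), lies beyond the scatter, so among these three compounds, the one bearing hydroxy stands apart from both amines, while the two amines cannot be told apart. No outside measurement accompanies these numbers, and nothing here explains either the gap to hydroxy or the absence of a gap between ethylamino and isopropylamino.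

The compounds shown leave open whether the flat result holds for other groups on the nitrogen, such as tert-butyl, cyclopropyl or a longer chain, or for a tertiary amine such as dimethylamino or a morpholine ring. They also leave open how a methoxy group or a carboxylic acid would compare with the hydroxy of compound 1 at this place.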